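Aryl replacement step in a somatostatin receptor series

The source may hold more compounds than are shown below. What is called first, only, known or untested is meant among the compounds shown, and "the series" means these compounds.

Measured so far:
compound 1 `COC(=O)c1cc(CC(C)CN2C[C@H]3CCCC[C@H]3[C@@H](C(=O)N3CCN(c4ccc([N+](=O)[O-])cc4)CC3)C2)cc(C(=O)OC)c1`: 107 nM
compound 2 `COC(=O)c1cc(C[C@H](C)CN2C[C@@H]3CCCC[C@@H]3[C@H](C(=O)N3CCN(c4ccc([N+](=O)[O-])cc4)CC3)C2)cc(C(=O)OC)c1`: 1.23 nM
compound 3 `C[C@@H](Cc1ccc2ocnc2c1)CN1C[C@@H]2CCCC[C@@H]2[C@H](C(=O)N2CCN(c3ccc(F)c(F)c3)CC2)C1`: 11 nM

In an assay on isolated protein for binding affinity to somatostatin receptor type 3 (Homo sapiens) (on this read-out lower numbers stand for tighter binding and higher numbers for weaker binding), compound 3 stands second highest of the three numbers, between compound 2 and compound 1. Compound 4 `Cc1cn2cc(C[C@H](C)CN3C[C@@H]4CCCC[C@@H]4[C@H](C(=O)N4CCN(c5ccc(F)c(F)c5)CC4)C3)ccc2n1` carries a group of 10 heavy atoms (8 carbon, 2 nitrogen; one five-membered aromatic ring with 2 hetero atoms, one six-membered aromatic ring with 1 hetero atom) in place of a group of 9 heavy atoms (7 carbon, 1 nitrogen, 1 oxygen; one five-membered aromatic ring with 2 hetero atoms, one six-membered aromatic ring of carbon only), on a saturated chain carbon, three bonds along the chain from an amine nitrogen in a ring. Going by the values given here, the only measured step, an 87-fold lower number from compound 1 to compound 2 (1.94 log units; beyond the scatter), rests on the drawn configuration alone the fact that one of compounds 1 and 2 is drawn with a defined configuration and the other without, at the place where they differ and leaves the aryl group untouched, so it gives no guide to the present change; compounds 1 and 2 differ from compound 3 in several places at once. Among the compounds with values here, no measured step therefore bears on this swap, and no change beyond the scatter is expected, a 1.1-fold higher number from compound 3 to compound 4 (0.04 log units; within the scatter). Compound 4 is expected to give 12 nM, within a range from 4 nM to 40 nM.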

Compound 4, dissociation constant: 107 nM
The estimate for compound 4 lay 8.9-fold (0.95 log units) below the measured number; the measured number lies above the stated range.
By their numbers in this assay, from the lowest: compound 2; then compound 3; then compounds 1 and 4 (each within the scatter of the next).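

In this assay, putting the group of 10 heavy atoms in place of 1,3-benzoxazol-5-yl gives a 9.7-fold higher number from compound 3 to compound 4 (0.99 log units; beyond the scatter), on a saturated chain carbon, three bonds along the chain from an amine nitrogen in a ring. Going by these compounds alone, this is the first read on the aryl group at this place, and it shows that the number responds to the swap even with hydrogen-bond donor and acceptor counts and net charge unchanged. Nothing at hand bears on why the step has this size.

Open, going by these compounds, is whether the methyl group on the entering ring system or the ring hetero atoms carry the step. Also open, on these data alone, is how a plain phenyl or a pyridine would read at this place.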